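A fluorophenyl exchange on the benzyl group of compound 1

The source may report more compounds than this note shows. Statements on the series, on what has been measured and on what is new or still open speak of the compounds shown alone.

Compound 1 `Fc1ccc(Cn2cc(CSC(=S)N3CCNCC3)nn2)cc1` was tested in a functional assay on MGC-803 cells (Homo sapiens) for inhibition, read by MTT assay, with a stated time of 72 h (a lower number here means a stronger inhibitor, a higher number a weaker inhibitor), and gave 32500 nM. Among the three measured compounds its number is the highest: compound 2 `Cc1ccc(Cn2cc(CSC(=S)N3CCN(C(=O)OC(C)(C)C)CC3)nn2)cc1` gives 3490 nM in this assay, a gap beyond the scatter, while compound 3 `O=C(OCc1ccccc1)N1CCN(C(=S)SCc2cn(Cc3ccc(F)cc3)nn2)CC1` gives 17600 nM, which sits within the scatter of compound 1. Among the measured compounds shown here, the only single-point step measured so far, a 1.8-fold lower number from compound 1 to compound 3 (0.27 log units; within the scatter), changes the amine nitrogen in the ring and not the benzyl group.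

Compound 4 `Fc1ccccc1Cn1cc(CSC(=S)N2CCNCC2)nn1` differs from compound 1 in one place: 2-fluorophenyl in place of 4-fluorophenyl on a saturated chain carbon bound to an aromatic nitrogen. For the measured compounds named here, no measured pair shows this kind of change, so nothing in the data points to a step in either direction. Going by the values given here, the one step recorded, from compound 1 to compound 3, concerns a different part of the molecule and was within the scatter, so it gives no guidance on the fluorophenyl exchange. The expectation for compound 4 in this assay is therefore no step beyond the scatter, expressed as a 1.1-fold lower number from compound 1 to compound 4 (0.03 log units; within the scatter). Compound 4 is expected to give 30000 nM, with a likely range from 10000 nM to 90000 nM.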

Compound 4, half-maximal inhibitory concentration: 19400 nM
Estimate against measurement, compound 4: 1.5-fold (0.19 log units) above; low and high end bracket the measured number.
By their numbers in this assay, from the lowest: compound 2; then compounds 3, 4 and 1 (each within the scatter of the next).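

Among the compounds shown here, compound 4 gives the first measured look at this position, on a saturated chain carbon bound to an aromatic nitrogen: in this assay, the exchange of 4-fluorophenyl for 2-fluorophenyl amounts to a 1.7-fold lower number from compound 1 to compound 4 (0.22 log units; within the scatter) and so cannot be told apart from repeat-measurement noise. For the compounds shown here, the two groups have the same atoms, joined differently, so in this one pair, rearranging the fluorophenyl group produces no readable difference, whereas the earlier compounds said nothing about this part of the molecule. No supporting measurement bears on this result, so the data offer no explanation for it.

The compounds shown leave open whether a different group at this place, such as plain phenyl, 4-chlorophenyl or 4-methoxyphenyl, would give a step beyond the scatter. They also leave open whether the 2-fluorophenyl group would behave the same way in a compound carrying benzyloxycarbonyl or tert-butoxycarbonyl on the amine nitrogen in the ring, since this exchange has been read only with hydrogen on that nitrogen.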